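The source may report more compounds than this note shows. Statements on the series, on what has been measured and on what is new or still open speak of the compounds shown alone.

Measured compounds:
- compound 1, `N#CC1=C(N)OC(c2c[nH]c3ccccc23)=C(C#N)C1c1ccccc1F`: "not active" (no number reported)
- compound 2, `CN(C)c1ccc(C2C(C#N)=C(N)OC(c3c[nH]c4ccccc34)=C2C#N)cc1`: 14.4%
- compound 3, `N#CC1=C(N)OC(c2c[nH]c3ccccc23)=C(C#N)C1c1ccccc1Cl`: 8.5%

Compound 3 stands lowest of the two numbers reported in a functional assay, tested at 50 ug/mL; a higher number here means a stronger effect of the compound at the concentration tested, a lower number a weaker effect; its nearest neighbour is compound 2, and the step of a number 5.9 percentage points lower from compound 2 to compound 3 (within the scatter) is within the scatter, so no order between the two can be claimed. Compound 1, which carries a 2-fluorophenyl group on the same saturated ring carbon, is reported only as not active in this assay, without a number.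

Compound 4, `N#CC1=C(N)OC(c2c[nH]c3ccccc23)=C(C#N)C1c1ccc(F)cc1`, differs from compound 3 in one place: 4-fluorophenyl in place of 2-chlorophenyl on a saturated ring carbon. Within the data shown here, no measured step swaps one halogen-bearing phenyl for another, so the only bearing comes from compound 2 to compound 3, where a much larger change in the same position gave a step within the scatter, and from compound 1, where a fluorophenyl group went with no reported activity. On that basis compound 4 is expected to give a weak read-out close to that of compound 3, with the step of a number 0.5 percentage points lower from compound 3 to compound 4 (within the scatter) estimated to lie within the scatter. The value expected for compound 4 in this assay is 8%, ranging from 0% to 18%.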

Compound 4, a percentage reported as activity, at one concentration (the size of the read-out at that concentration, not a potency): 8.4%
For compound 4 the middle estimate is 0.4 percentage points below the measured one; the measured number falls inside the stated range.
By their numbers in this assay, from the lowest: compounds 4, 3 and 2 (each within the scatter of the next).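

In this assay, among these compounds, the saturated ring carbon now yields a first step between two halogen-bearing phenyl groups, and that step is a number 0.1 percentage points lower from compound 3 to compound 4 (within the scatter) so 4-fluorophenyl and 2-chlorophenyl cannot be told apart at this position. Fluoro in place of dimethylamino on an aromatic carbon gives a number 6 percentage points lower from compound 2 to compound 4 (within the scatter) and so this change, too, separates nothing, while compound 1 is reported as "not active" (no number reported) and its steps to the other compounds cannot be read. Nothing at hand explains these read-outs.

Going by these compounds, whether a carboxylic acid or a methoxy group on the phenyl ring, or a piperidine in its place, would move the read-out beyond the scatter stays open. Also open is what the 1H-indol-3-yl group contributes, as it is the same in every compound shown.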